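Chloro to hydrogen at two places in a fused-core amide series

The compounds below may be only part of what the source reports. "The series", "measured", "known", "first", "only" and "open" are said of these compounds alone.

Measured compounds, with their values in an assay on membranes from brain for displacement of a labelled ligand from adenosine receptor A1 (Rattus norvegicus), read by scintillation counting, with a stated time of 90 min; a lower number here means a stronger inhibitor, a higher number a weaker inhibitor:
Compound 1, `O=C(CCCc1ccccc1)Nc1nc2ccc(Cl)cc2c(=O)s1`, gives a limit of the assay, > 10000 nM.
Compound 2, `O=C(CCCc1ccccc1)Nc1nc2ccccc2c(=O)s1`, gives 229 nM.
Compound 3, `O=C(C/C=C/c1cccc(Cl)c1)Nc1nc2ccccc2c(=O)s1`, gives 11.4 nM.

Compound 1 and compound 2 share the core and the amide side chain and differ in one place: hydrogen in place of chloro on an aromatic carbon. The step is an at least 43-fold lower number from compound 1 to compound 2 (1.64 log units; beyond the scatter). Its size rests on (the limit of > 10000 nM in this assay, at which 1 of the 3 values shown sits), so only its lower bound is known. Compound 3 carries a different side chain; the difference between compound 3 and compound 1 is not broken down here. Compound 3 gives the lowest of the two measured numbers.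

Compound 4, `O=C(C/C=C/c1ccccc1)Nc1nc2ccccc2c(=O)s1`, is not yet measured in this assay. It differs from compound 3 in one place: hydrogen in place of chloro on an aromatic carbon. This is the same kind of change as that from compound 1 to compound 2, but not the same: there the place was on a six-membered aromatic ring of carbon only, part of a fused or bridged system of two rings, meta to a fused ring and para to a fused ring; here it is on a six-membered aromatic ring of carbon only, meta to a large group, in the side chain. For compound 4 a step of a 1.6-fold higher number from compound 3 to compound 4 (0.20 log units; within the scatter) is expected, smaller than the earlier one, since an at least 43-fold lower number from compound 1 to compound 2 (1.64 log units; beyond the scatter) was measured at a different place and is taken only as a loose guide. Compound 4 is estimated at 18 nM, between 5 nM and 60 nM.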

Compound 4, inhibition constant: 53 nM
The estimate for compound 4 lay 2.9-fold (0.47 log units) below the measured number; low and high end bracket the measured number.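

In this assay, the change from 3-chlorophenyl to phenyl in the side chain gives a 4.6-fold higher number from compound 3 to compound 4 (0.67 log units; beyond the scatter), so hydrogen in place of chloro raises the number here, while the same exchange on the core lowered it, and the step therefore does not carry over from one place to the other in direction or in size: the same change on two cores in this assay, an at least 43-fold lower number (1.64 log units; beyond the scatter) from compound 1 to compound 2 and a 4.6-fold higher number (0.67 log units; beyond the scatter) from compound 3 to compound 4, at least 200-fold (2.30 log units) apart, beyond the scatter of two such steps. The earlier step is known only as a lower bound, as compound 1 stands at a limit of the assay and not at a measured number: the limit of > 10000 nM in this assay, at which 1 of the 4 values shown sits. The comparison rests on a single pair at each place, and the two pairs also differ in their side chains, so it does not show whether the place of the chloro or the side chain around it sets the difference, nor does it give any reason for the opposite directions.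

Open, from the compounds shown here alone, is whether the chloro on the core lowers binding as sharply when the side chain is that of compound 4 as it does with the side chain of compound 2. Also open, going by these compounds, is whether a fluoro or a methoxy group at the place of the side-chain chloro would follow compound 3 or compound 4.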